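Cyclopropylamino for Pyrrolidinyl on a Shared Pyrimidine Core

The source may hold more compounds than are shown below. What is called first, only, known or untested is meant among the compounds shown, and "the series" means these compounds.

Compound 1, `O=C(Nc1ccccc1)Nc1nc(NC2CC2)cc(Sc2c[nH]c3ccccc23)n1`, gives 17500 nM in a functional assay on PC-3 cells (Homo sapiens) for inhibition, with a stated time of 72 h; a higher number here means a weaker inhibitor, a lower number a stronger inhibitor. Compound 2, `O=C(Nc1ccccc1)Nc1nc(Sc2c[nH]c3ccccc23)cc(N2CCCC2)n1`, gives 14900 nM. Compound 3, `Cc1cc(Cl)ccc1NC(=O)Nc1nc(Sc2c[nH]c3ccccc23)cc(N2CCCC2)n1`, gives 12900 nM.

Compound 4, `Cc1cc(Cl)ccc1NC(=O)Nc1nc(NC2CC2)cc(Sc2c[nH]c3ccccc23)n1`, has not yet been measured in this assay. It differs from compound 3 by cyclopropylamino in place of pyrrolidin-1-yl on an aromatic carbon. The same kind of change separates compound 2 from compound 1, namely (cyclopropylamino in place of pyrrolidin-1-yl on an aromatic carbon), where the place is described as meta to a (phenylcarbamoyl)amino group rather than meta to a large group; that change gave a 1.2-fold higher number from compound 2 to compound 1 (0.07 log units; within the scatter). The two cores differ by 4-chloro-2-methylphenyl in place of phenyl on an amide-type nitrogen, which gave a 1.2-fold lower number from compound 2 to compound 3 (0.06 log units; within the scatter).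

For compound 4 the expected step is therefore a 1.2-fold higher number from compound 3 to compound 4 (0.08 log units; within the scatter), resting on the step from compound 2 to compound 1. Compound 4 is estimated at 15500 nM, between 8000 nM and 30000 nM.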

Compound 4, half-maximal inhibitory concentration: 11100 nM
Beside the measured number, compound 4's estimate is 1.4-fold (0.15 log units) above it; the measured number falls inside the stated range.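

In this assay, cyclopropylamino in place of pyrrolidin-1-yl gives a 1.2-fold lower number from compound 3 to compound 4 (0.07 log units; within the scatter), and this step does not differ from the one seen on the other core: the same change on two cores in this assay, a 1.2-fold higher number (0.07 log units; within the scatter) from compound 2 to compound 1 and a 1.2-fold lower number (0.07 log units; within the scatter) from compound 3 to compound 4, 1.4-fold (0.14 log units) apart, within the scatter of two such steps. The 4-chloro-2-methylphenyl for phenyl change gives a 1.6-fold lower number from compound 1 to compound 4 (0.20 log units; within the scatter), and it too agrees with its earlier counterpart: the same change on two cores in this assay, a 1.2-fold lower number (0.06 log units; within the scatter) from compound 2 to compound 3 and a 1.6-fold lower number (0.20 log units; within the scatter) from compound 1 to compound 4, 1.4-fold (0.14 log units) apart, within the scatter of two such steps. Across these two cores, both changes thus leave the number within the scatter, but this shows only that neither produced a readable step, not that a real effect carries from one core to the other.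

The compounds shown leave open whether morpholine or a longer amine chain at this place would give a step beyond the scatter. From the compounds shown here alone, whether such a step would hold on both cores also remains open.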